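A few compounds are considered here, and "the series" means these few. Any claim that something is new, unique, unknown or untested is made for them only; others in the source may bear on it.

Measured so far in a functional assay on 143B cells (Homo sapiens) for antiproliferative activity, read by MTT assay, with a stated time of 48 h; a higher number here means a weaker inhibitor, a lower number a stronger inhibitor:
compound 1 `O=C(/C=C/c1cccc(NC(=O)c2ccccc2Br)c1)c1nc2ccccc2[nH]1` gives 6050 nM
compound 2 `COc1cccc(C(=O)Nc2cccc(/C=C/C(=O)c3nc4ccccc4[nH]3)c2)c1` gives 4610 nM
compound 3 `O=C(Nc1cccc(/C=C/C(=O)c2nc3ccccc3[nH]2)c1)c1cc(Cl)cc(Cl)c1` gives 3660 nM

Compound 1 has the highest of the three numbers; its nearest neighbour is compound 2, with a 1.3-fold lower number from compound 1 to compound 2 (0.12 log units; within the scatter), and the furthest is compound 3, with a 1.7-fold lower number from compound 1 to compound 3 (0.22 log units; within the scatter). Between the other two the step is a 1.3-fold lower number from compound 2 to compound 3 (0.10 log units; within the scatter). All three steps lie within the scatter, so no order among the measured compounds is claimed. Each of these steps changes only the aryl group on the carbonyl carbon.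

Compound 4 `O=C(/C=C/c1cccc(NS(=O)(=O)c2ccccc2Cl)c1)c1nc2ccccc2[nH]1` is not yet measured. It differs from compound 1 in (2-chlorophenyl)sulfonyl in place of (2-bromophenyl)carbonyl on a nitrogen on an aromatic ring. Among the compounds with values here, no measured step exchanges the carbonyl itself for a sulfonyl, so none of the three steps bears directly on this change; what is known is only that varying the aryl group on the carbonyl left the numbers within the scatter. Compound 4 is therefore expected to give a number close to that of compound 1, with the range widened to allow either direction. The expected step is a 1.0-fold lower number from compound 1 to compound 4 (0.00 log units; within the scatter). For compound 4 in this assay the estimate is 6000 nM, with a range from 2000 nM to 18000 nM.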

Compound 4, half-maximal inhibitory concentration: 4790 nM
Beside the measured number, compound 4's estimate is 1.3-fold (0.10 log units) above it; measured number inside the range.
By their numbers in this assay, from the lowest: compounds 3, 2, 4 and 1 (each within the scatter of the next).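

In this assay, the exchange on a nitrogen on an aromatic ring gives a 1.3-fold lower number from compound 1 to compound 4 (0.10 log units; within the scatter) and so extends the flat picture from the aryl group to the carbonyl itself: a sulfonyl at this place leaves the number within the scatter. Against the other two carbonyl compounds the comparison reads the same, with a 1.3-fold higher number from compound 3 to compound 4 (0.12 log units; within the scatter) and a 1.0-fold higher number from compound 2 to compound 4 (0.02 log units; within the scatter) and no separation among the four compounds. Nothing available explains this lack of separation.

Because this exchange also replaces bromine with chlorine on the aryl group, the contribution of the sulfonyl alone remains unresolved. Also open, from the compounds shown here alone, is whether a carboxylic acid or an amine on that aryl group, or a longer chain in its place, would give a step beyond the scatter.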